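Moving a trifluoromethyl group on a thiocarbonyl core

A few compounds are considered here, and "the series" means these few. Any claim that something is new, unique, unknown or untested is made for them only; others in the source may bear on it.

Compound 1 `CC(O)(CSc1cccc(S(F)(F)(F)(F)F)c1)C(=O)Nc1ccc([N+](=O)[O-])c(C(F)(F)F)c1`: 8800 nM
Compound 2 `CC(O)(CSc1cc(C(F)(F)F)cc(C(F)(F)F)c1)C(=O)Nc1ccc(S(F)(F)(F)(F)F)cc1`: 15800 nM
Compound 3 `CC1(C)C(=O)N(c2cccc(S(F)(F)(F)(F)F)c2)C(=S)N1c1ccc(C(F)(F)F)cc1`: 22400 nM

These three values were all obtained in a functional assay on CWR22R cells (Homo sapiens) for antiproliferative activity, read by propidium iodide staining, with a stated time of 96 h (a higher number here means a weaker inhibitor, a lower number a stronger inhibitor), and the three compounds do not form any pair that differs in a single place. Compound 3 sits at the upper end of this small set. At 22400 nM, compound 3 cannot be told apart from compound 2 at 15800 nM, as the two lie within the scatter of each other. Compound 1, at 8800 nM, gives a lower number than compound 3, and that gap lies beyond the scatter.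

The next compound to be measured is compound 4 `CC1(C)C(=O)N(c2cccc(S(F)(F)(F)(F)F)c2)C(=S)N1c1cccc(C(F)(F)F)c1`. It carries 3-(trifluoromethyl)phenyl in place of 4-(trifluoromethyl)phenyl on an amide-type nitrogen in a ring. Compounds 3 and 4 have the same atoms, joined differently.

Among the compounds with values here, no measured pair shows what such a change does in this assay, so the only anchor is compound 3 at 22400 nM. No step beyond the scatter is expected, and neither direction is favoured with any confidence. The estimated change is a 1.1-fold lower number from compound 3 to compound 4 (0.05 log units; within the scatter). The expected value for compound 4 is 20000 nM, within an estimated range of 9000 nM to 42000 nM.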

Compound 4, half-maximal inhibitory concentration: 100000 nM
For compound 4 the middle estimate is 5.0-fold (0.70 log units) below the measured one; the measured number lies above the stated range.
By their numbers in this assay, from the lowest: compounds 1, 2 and 3 (each within the scatter of the next, the first and the last beyond it); then compound 4.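

Within the data shown here, compound 3 and compound 4 form the first pair in this set that differs in one place, and they give a first direct reading of this position. Among these compounds, with the same atoms joined differently, placing 3-(trifluoromethyl)phenyl in place of 4-(trifluoromethyl)phenyl on the amide-type nitrogen in the ring gives a 4.5-fold higher number from compound 3 to compound 4 (0.65 log units; beyond the scatter) in this assay, so the point of attachment of the trifluoromethyl group on this phenyl ring matters, a step the earlier compounds could not reveal. No measurement offered here accounts for this step, so its cause remains unexplained.

This reading rests on a single pair, and it cannot yet be said whether the same step would appear with another partner on the other ring nitrogen of the shared core. Also open, going by these compounds, is how a nitrile, a chlorine atom or a methoxy group would fare on this phenyl ring in place of the trifluoromethyl group, and whether any of these would follow the same order between the two attachment points.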